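Trimming the biaryl of compound 1 down to a plain benzyl

The compounds below may be only part of what the source reports. "The series", "measured", "known", "first", "only" and "open" are said of these compounds alone.

Measured compounds:
- compound 1, `COC(=O)/C=C/c1cccc(N(Cc2ccc(-c3ccc(F)c(F)c3)cc2)C(=O)C2CCCCC2)c1`: 72 nM
- compound 2, `COC/C=C/c1cccc(N(Cc2ccc(/C=C/C(=O)OC(C)(C)C)cc2)C(=O)C2CCCCC2)c1`: 243 nM

Both compounds were tested in an assay on isolated protein with Bile acid receptor (Homo sapiens) as the target; a higher number here means that more compound is needed for the effect, a lower number that less compound is needed. Compound 1 gives 72 nM, and that is the lowest of the two numbers; compound 2 gives 243 nM, a higher number by a margin that lies beyond the usual scatter of the assay. The two compounds differ in more than one place, so no single change can be read out of their gap.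

Compound 3, `COC(=O)/C=C/c1cccc(N(Cc2ccccc2)C(=O)C2CCCCC2)c1`, has not been measured in this assay. It is derived from compound 1 by one change:

hydrogen in place of 3,4-difluorophenyl on an aromatic carbon

A sizeable piece of compound 1 is thus removed and nothing but a hydrogen remains in its place. Going by the values given here, no measured pair shows what such a removal does here, so the expectation rests only on the size of what is lost. Compound 3 is expected to need more compound than compound 1, with an estimated step of an 8.3-fold higher number from compound 1 to compound 3 (0.92 log units; beyond the scatter) that goes beyond the scatter. The estimate for compound 3 in this assay is 600 nM, within a range from 150 nM to 3000 nM.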

Compound 3, half-maximal effective concentration: > 1000 nM
Compound 3: only a limit was reported; the forecaster's own chance of this, stated with the estimate: 10%; middle value at least 1.6-fold (0.22 log units) away from the limit.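

In this assay, replacing the 3,4-difluorophenyl of compound 1 with a single hydrogen gives an at least 13-fold higher number from compound 1 to compound 3 (1.14 log units; beyond the scatter), a large step beyond the scatter and the only comparison shown in which just one place changes. Compound 3 gives > 1000 nM, which is a limit of the assay and not a number. This is the first direct sign that much of the low number of compound 1 depends on what sits at this aromatic carbon, para to a large group, though the full size of the loss cannot be given, and the reading rests on this one result: the limit of > 1000 nM in this assay, at which 1 of the 3 values shown sits.

The compounds shown leave open whether the whole aromatic ring is required or the two fluorines also contribute, and a plain phenyl at this carbon would separate those two parts, while a methyl or a single chlorine atom would show whether a much simpler group can take its place. Compound 2 carries a different group at this carbon but also differs elsewhere, so it cannot settle either question.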